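Replacing Isopropyl with 4-Bromobenzyl on the Amine Nitrogen

This account rests on a few compounds, and the source may have more. Where it says the series, first, only, none or still open, it means among the compounds named here.

Compound 3 `CC(C)Nc1nc(/C=C/c2ccccc2)nc2ccsc12` reaches in a functional assay on L02 cells (Homo sapiens) for inhibition, read by Griess assay, with stated times of 1 h and 24 h (on this read-out lower numbers stand for stronger inhibition and higher numbers for weaker inhibition), only a limit of the assay, > 1000000 nM. Compound 1 `CCCc1nn(C)c2c(NCc3ccc(F)cc3)nc(/C=C/c3nc(C)c(C)nc3C)nc12` likewise returns a limit in this assay, > 1000000 nM. Compound 2 `COc1cc(/C=C/c2nccc(NC(C)C)n2)cc(OC)c1OC` stops at a limit on the opposite side in this assay, < 40000 nM. Compound 3 therefore sits at the limit of > 1000000 nM in this assay, at which 2 of the 3 values shown sit, as does compound 1. Compound 2 sits at the limit of < 40000 nM in this assay, at which 1 of the 3 values shown sits. None of the three supplies an actual number. Compound 4 `Brc1ccc(CNc2nc(/C=C/c3ccccc3)nc3ccsc23)cc1` carries 4-bromobenzyl in place of isopropyl on a nitrogen on an aromatic ring. Compound 1 and compound 3 both stop at their limits, and nothing among these three points to a gain from the change. The step of a number no higher from compound 3 to compound 4 (the limit leaves the size open) is expected to stay within the scatter. Compound 4 is estimated at 1000000 nM, within a range from 100000 nM to 3000000 nM, most probably reported once more as a limit.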

Compound 4, half-maximal inhibitory concentration: > 1000000 nM
Compound 4 was reported as a limit (the forecaster's own chance of this, stated with the estimate: 75%); the middle value sits exactly at the limit.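

Compound 3 and compound 4 both stop at a limit of the assay, and no step can be read between them. The compounds shown leave open whether 4-bromobenzyl in place of isopropyl on a nitrogen on an aromatic ring alters inhibition in this assay at all.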